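The compounds below may be only part of what the source reports. "The series", "measured", "known", "first", "only" and "open" are said of these compounds alone.

Working notes on the series. Three compounds have been run in a functional assay on HeLa cells (Homo sapiens) for inhibition, read by MTT assay; on this read-out higher numbers stand for weaker inhibition and lower numbers for stronger inhibition. Compound 1 `CCCCCCCCn1cc(/C=C/C(=O)c2ccc(NC(=O)CN3CCN(c4ccccc4OC)CC3)cc2)nn1` gives 26800 nM in this assay, compound 2 `CCCCCCCCn1cc(/C=C/C(=O)c2ccc(NC(=O)CN3CCN(c4ccccc4)CC3)cc2)nn1` gives 33800 nM, and compound 3 `CCCCCCCCCCn1cc(/C=C/C(=O)c2ccc(NC(=O)CN3CCN(c4ccc([N+](=O)[O-])cc4)CC3)cc2)nn1` gives 65900 nM. Compound 3 holds the highest number of the three: the gap to compound 2 is within the scatter, while the gap to compound 1 is beyond it.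

Going by the values given here, the only single-point step so far, a 1.3-fold higher number from compound 1 to compound 2 (0.10 log units; within the scatter), changes a substituent on the aromatic ring at the far end of the molecule and stays within the scatter. It does not touch the chain on the aromatic nitrogen.

Compound 4 `CCCCCCCCn1cc(/C=C/C(=O)c2ccc(NC(=O)CN3CCN(c4ccc([N+](=O)[O-])cc4)CC3)cc2)nn1` differs from compound 3 by hydrogen in place of ethyl on a saturated chain carbon, eight bonds along the chain from an aromatic nitrogen. Among the compounds with values here, no measured pair isolates this change: compounds 1 and 2 carry the shorter chain but also a different aryl substituent than compound 3, so their lower numbers cannot be assigned to the chain alone. Within the data shown here, the change is small and remote from the remainder of the molecule, and the one measured step in this assay was flat; the expectation for compound 4 is therefore no step beyond the scatter, a 1.3-fold lower number from compound 3 to compound 4 (0.12 log units; within the scatter), with only a loose lean toward the lower values of compounds 1 and 2.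

Compound 4 is estimated at 50000 nM in this assay, expected between 22000 nM and 115000 nM.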

Compound 4, half-maximal inhibitory concentration: 30200 nM
Estimate against measurement, compound 4: 1.7-fold (0.22 log units) above, within the range that was stated.
By their numbers in this assay, from the lowest: compounds 1, 4, 2 and 3 (each within the scatter of the next, the first and the last beyond it).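

Going by these compounds alone, the step in this assay, a 2.2-fold lower number from compound 3 to compound 4 (0.34 log units; beyond the scatter), is the first single-change reading on the chain on the aromatic nitrogen: hydrogen in place of ethyl, eight bonds along the chain from that nitrogen, gives a modest shift toward stronger inhibition, so this position is not silent in the way the one earlier step at the aromatic ring had suggested. With the chain of compound 4 held fixed, the far aromatic ring stays flat: nitro in place of hydrogen gives a 1.1-fold lower number from compound 2 to compound 4 (0.05 log units; within the scatter), and 4-nitrophenyl in place of 2-methoxyphenyl gives a 1.1-fold higher number from compound 1 to compound 4 (0.05 log units; within the scatter), so compounds 1, 2 and 4 read as one group while only compound 3 stands apart from compound 1. No measurement bearing on the reason for the chain step is at hand.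

Going by these compounds, the chain comparison rests on a single pair, and the longer chain of compound 3 appears here only with 4-nitrophenyl, so it remains open whether the same step holds with phenyl or 2-methoxyphenyl at the far end. Also open, on these data alone, is how the number responds to a shorter chain still, to a chain longer than that of compound 3, or to a chain carrying an amine or a carboxylic acid.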